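Extending the thioether of compound 2 toward compound 3

This account rests on a few compounds, and the source may have more. Where it says the series, first, only, none or still open, it means among the compounds named here.

Compound 1, `Cn1nc(-c2nnc(SCc3cccc([N+](=O)[O-])c3)o2)cc1-c1ccc(C(F)(F)F)cc1`, gives > 100000 nM in a functional assay on MCF7 cells (Homo sapiens) for cytotoxicity, read by MTT assay, with a stated time of 24 h; on this read-out lower numbers stand for stronger inhibition and higher numbers for weaker inhibition.
Compound 2, `Cn1nc(-c2ccc(C(F)(F)F)cc2)cc1-c1nnc(S)o1`, gives > 100000 nM in this assay.

Each of these values is a limit of this assay and not a number. Compound 2 therefore stands at the limit of > 100000 nM in this assay, at which 2 of the 2 values shown sit. Compound 3, `Cn1nc(-c2ccc(C(F)(F)F)cc2)cc1-c1nnc(SCCOc2ccccc2F)o1`, differs from compound 2 by 2-(2-fluorophenoxy)ethyl in place of hydrogen on a sulfur. No measured step separates two of these compounds, so the expectation rests on the limits alone: the step of an at least 1.1-fold lower number from compound 2 to compound 3 (0.04 log units; that floor lies within the scatter) is expected to be small, not beyond the usual scatter, and compound 3 may again return only a limit. Compound 3 is estimated at 90000 nM, within 25000 nM to 300000 nM.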

Compound 3, half-maximal inhibitory concentration: 33300 nM
Compound 3: the middle estimate sits 2.7-fold (0.43 log units) above what was measured; the measured number falls inside the stated range.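

Placing 2-(2-fluorophenoxy)ethyl in place of hydrogen on the sulfur gives a real number in this assay, and the change is beyond the scatter, with an at least 3.0-fold lower number from compound 2 to compound 3 (0.47 log units; beyond the scatter). This shows that substitution at this sulfur can move the read-out, which the limit of compound 2 alone could not show. Compound 2 gives only a limit, so the step is a floor and its true size is unknown: the limit of > 100000 nM in this assay, at which 2 of the 3 values shown sit.

Whether the fluorine, the ether oxygen or the aromatic ring accounts for the step remains open. So does whether a longer chain or a terminal amine on this sulfur would do the same.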